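Biaryl in place of the stilbene arm of the series

The source may hold more compounds than are shown below. What is called first, only, known or untested is meant among the compounds shown, and "the series" means these compounds.

Compound 1 `COC(=O)/C=C/c1cccc(N(Cc2ccc(/C=C/c3cccc(Cl)c3)cc2)C(=O)C2CCCCC2)c1` and compound 2 `COC(=O)/C=C/c1cccc(N(Cc2ccc(/C=C/c3ccc(F)cc3)cc2)C(=O)C2CCCCC2)c1` share one core. In an assay on isolated protein with Bile acid receptor (Homo sapiens) as the target (on this read-out higher numbers stand for an effect only at larger amounts of compound and lower numbers for an effect already at smaller amounts), compound 1 gives 166 nM and compound 2 gives 186 nM, a step of a 1.1-fold higher number from compound 1 to compound 2 (0.05 log units; within the scatter). Compound 2 thus stands alongside compound 1, the two numbers within the scatter of one another. Compound 3 `COC(=O)/C=C/c1cccc(N(Cc2ccc(-c3cccc(OC(F)(F)F)c3)cc2)C(=O)C2CCCCC2)c1` differs from compound 2 by 3-(trifluoromethoxy)phenyl in place of 2-(4-fluorophenyl)ethenyl on an aromatic carbon. Among the compounds with values here, no measured step touches this change; the single step known only swaps one halogenated phenyl for another and stays within the scatter. For compound 3 the expected step is a 1.3-fold higher number from compound 2 to compound 3 (0.13 log units; within the scatter), small and uncertain. The estimate for compound 3 is 250 nM, range 90 nM to 700 nM.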

Compound 3, half-maximal effective concentration: 417 nM
For compound 3 the middle estimate is 1.7-fold (0.22 log units) below the measured one; the range from low to high includes it.
By their numbers in this assay, from the lowest: compounds 1 and 2 (each within the scatter of the next); then compound 3.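

At this aromatic carbon, para to a large group, replacing the whole arm moves the read-out beyond the scatter, which the earlier swap of phenyl groups on the ethenyl arm did not do. In this assay, 3-(trifluoromethoxy)phenyl entering gives a 2.2-fold higher number from compound 2 to compound 3 (0.35 log units; beyond the scatter) and a 2.5-fold higher number from compound 1 to compound 3 (0.40 log units; beyond the scatter), both modest. No supporting data bear on why the number rises.

The change removes the double bond and alters the ring substituent together, and these two effects remain unseparated. On these data alone, an amine or carboxylic acid on the entering phenyl also remains open.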